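The source may report more compounds than this note shows. Statements on the series, on what has been measured and on what is new or still open speak of the compounds shown alone.

Compound 3, `CS(=O)(=O)Nc1ccc2[nH]c(Cc3ccc(Oc4ccccc4)cc3)nc2c1`, is the weakest-looking of the three measured compounds in an assay on membranes from brain for binding affinity to Adrenergic receptor alpha-1 (Rattus norvegicus) (on this read-out higher numbers stand for weaker inhibition and lower numbers for stronger inhibition), where compound 3 gives 4000 nM. Its nearest neighbour is compound 2, `N#Cc1ccc2[nH]c(Cc3ccc(Oc4ccccc4)cc3)nc2c1`, which in this assay gives 3400 nM; the furthest is compound 1, `c1ccc(CC2CCN(Cc3nc4ccccc4[nH]3)CC2)cc1`, which gives 2800 nM. Both gaps sit within the scatter, so the three compounds cannot be ranked. Going by the values given here, the one measured step, a 1.2-fold higher number from compound 2 to compound 3 (0.07 log units; within the scatter), shows that swapping a cyano for a methanesulfonamido left the number essentially unchanged.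

Compound 4, `CN(c1ccc2[nH]c(Cc3ccc(Oc4ccccc4)cc3)nc2c1)S(C)(=O)=O`, differs from compound 3 by methyl in place of hydrogen on a sulfonamide nitrogen. Among the compounds with values here, no measured step touches this nitrogen, so the expectation rests on the small size of the change and on the flat step already seen; compound 4 is expected to show a step of a 1.1-fold higher number from compound 3 to compound 4 (0.05 log units; within the scatter), and its estimate is 4500 nM, with a range from 1800 nM to 11000 nM.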

Compound 4, half-maximal inhibitory concentration: 2000 nM
Compound 4: middle estimate off by 2.3-fold (0.35 log units), on the high side; the range from low to high includes it.
By their numbers in this assay, from the lowest: compounds 4, 1, 2 and 3 (each within the scatter of the next).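

In this assay, methyl in place of hydrogen on the sulfonamide nitrogen gives a 2.0-fold lower number from compound 3 to compound 4 (0.30 log units; within the scatter) and so produces no readable change, which means this hydrogen is not shown to matter here. Methyl(methylsulfonyl)amino in place of cyano gives a 1.7-fold lower number from compound 2 to compound 4 (0.23 log units; within the scatter) as well, so cyano, methanesulfonamido and methyl(methylsulfonyl)amino cannot be told apart on this aromatic carbon. Nothing available explains this flatness. Still open, going by these compounds, is whether an amine or a carboxylic acid on that aromatic carbon, or a longer chain such as propyl on the sulfonamide nitrogen, would move the number beyond the scatter.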